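Swapping the amide substituent for a piperidine ring

The compounds below may be only part of what the source reports. "The series", "measured", "known", "first", "only" and "open" are said of these compounds alone.

Compound 3 `O=C(NCc1ccsc1)c1ccc(C#Cc2ccccc2)nc1` gives the lowest number of the three compounds in a functional assay on BHK cells for positive allosteric modulation of metabotropic glutamate receptor 5 (Homo sapiens), read by FLIPR and calcium flux (a lower number here means that less compound is needed, a higher number that more compound is needed for the effect), at 140 nM. Compound 1 `O=C(NC1CCCCC1)c1ccc(C#Cc2ccccc2)nc1` gives 240 nM, and the step of a 1.7-fold lower number from compound 1 to compound 3 (0.23 log units; within the scatter) lies within the scatter. Compound 2 `CC1CCC(NC(=O)c2ccc(C#Cc3ccccc3)nc2)CC1` gives 1200 nM; the step of an 8.6-fold lower number from compound 2 to compound 3 (0.93 log units; beyond the scatter) and the step of a 5.0-fold higher number from compound 1 to compound 2 (0.70 log units; beyond the scatter) are beyond it. Compound 4 `O=C(c1ccc(C#Cc2ccccc2)nc1)N1CCCCC1` differs from compound 3 by piperidin-1-yl in place of ((thiophen-3-yl)methyl)amino on a carbonyl carbon. For the measured compounds named here, no measured step removes the amide hydrogen; the only change on the amide nitrogen, a 1.7-fold lower number from compound 1 to compound 3 (0.23 log units; within the scatter), stayed within the scatter, while adding a methyl on a saturated ring raised the number. Compound 4 is therefore expected to give 1500 nM, between 300 nM and 10000 nM, a step of an 11-fold higher number from compound 3 to compound 4 (1.03 log units; beyond the scatter).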

Compound 4, half-maximal effective concentration: 280 nM
The estimate for compound 4 lay 5.4-fold (0.73 log units) above the measured number; measured number outside the range, below it.
By their numbers in this assay, from the lowest: compounds 3, 1 and 4 (each within the scatter of the next); then compound 2.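

Compound 4 carries piperidin-1-yl, so it has no amide hydrogen, yet a 2.0-fold higher number from compound 3 to compound 4 (0.30 log units; within the scatter) and a 1.2-fold higher number from compound 1 to compound 4 (0.07 log units; within the scatter) both lie within the scatter. Among these compounds, then, the carbonyl carbon's substituent does not need that hydrogen, and a 4.3-fold lower number from compound 2 to compound 4 (0.63 log units; beyond the scatter) is the only new step beyond the scatter. Nothing available explains these results.

Still open, from the compounds shown here alone, is whether other rings, such as morpholine, fit here as well. A methyl-bearing piperidine could show whether a methyl raises the number on this ring, as it does from cyclohexyl in compound 1 to 4-methylcyclohexyl in compound 2.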